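A new aromatic group on the carbonyl carbon

This account rests on a few compounds, and the source may have more. Where it says the series, first, only, none or still open, it means among the compounds named here.

In an ADME assay on MT4 cells (Homo sapiens) for cytotoxicity, read by MTT assay (on this read-out higher numbers stand for lower toxicity in this test and lower numbers for higher toxicity in this test), compound 1 (`O=C1c2ccccc2C(=O)N1CCOC(=S)N(C(=O)c1cc(F)ccc1F)c1ccc(Cl)cc1`) gives 54000 nM and compound 2 (`COc1cccc(OC)c1C(=O)N(C(=S)OCCN1C(=O)c2ccccc2C1=O)c1ccc(Cl)cc1`) gives 69000 nM so these two stand within the scatter of each other. Compound 3 (`O=C1c2ccccc2C(=O)N1CCOC(=S)N(C(=O)c1ccc([N+](=O)[O-])cc1Cl)c1ccc(Cl)cc1`) has 2-chloro-4-nitrophenyl in place of 2,6-dimethoxyphenyl on a carbonyl carbon. For the measured compounds named here, the only measured step at that place (a 1.3-fold higher number from compound 1 to compound 2 (0.11 log units; within the scatter)) put 2,6-dimethoxyphenyl in place of 2,5-difluorophenyl and stayed within the scatter. One small step is thin evidence, so the step expected in this assay (a 1.4-fold lower number from compound 2 to compound 3 (0.14 log units; within the scatter)) is none beyond the scatter. For compound 3 the estimated value is 50000 nM with an expected range of 20000 nM to 100000 nM as the likely span.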

Compound 3, half-maximal cytotoxic concentration: 19000 nM
The estimate for compound 3 lay 2.6-fold (0.42 log units) above the measured number, and the stated range ends above it.
By their numbers in this assay, from the lowest: compound 3; then compounds 1 and 2 (each within the scatter of the next).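

For the compounds shown here, with 2-chloro-4-nitrophenyl on the carbonyl carbon, this position moves the number in this assay beyond the scatter for the first time: there is a 3.6-fold lower number from compound 2 to compound 3 (0.56 log units; beyond the scatter) and a 2.8-fold lower number from compound 1 to compound 3 (0.45 log units; beyond the scatter). Both steps point toward higher toxicity in this test, whereas the earlier exchange between two other substituted phenyl groups did not move the number beyond the scatter. No measurement shown here accounts for this shift.

On these data alone, the chlorine and the nitro group enter together, so which of them goes with the step stays open. A plain 2-chlorophenyl or 4-nitrophenyl group on the carbonyl carbon would separate the two.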